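Methoxymethyl to ethoxymethyl: working notes on the series

The source may report more compounds than this note shows. Statements on the series, on what has been measured and on what is new or still open speak of the compounds shown alone.

Measured compounds, both in a functional assay on MES-SA cells (Homo sapiens) for inhibition, with a stated time of 72 h, in the presence of a further agent that is not named here (a lower number here means a stronger inhibitor, a higher number a weaker inhibitor), as read-out:
compound 1 `Oc1c(CN2CCCC2)cc(Cl)c2cccnc12` - 4340 nM; 4270 nM (2 entries)
compound 2 `COCc1cc(CN2CCCC2)c(O)c2ncccc12` - 10500 nM

Among the compounds with values here, compound 2 stands at 10500 nM on the numbers so far. That is a higher number, and so a weaker reading, than both entries of compound 1 at 4340 nM; 4270 nM (2 entries) in the same test. The two entries of compound 1 lie close together. Within the data shown here, no measured pair differs in one place only, so the series offers no direct measure of a single change.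

The next compound is compound 3 `CCOCc1cc(CN2CCCC2)c(O)c2ncccc12` with ethoxymethyl where compound 2 has methoxymethyl. The change is methyl in place of hydrogen on a saturated chain carbon bound to an oxygen on a saturated carbon on a saturated chain carbon bound to an oxygen on a saturated carbon. No shift beyond the usual scatter is expected in this assay in either direction. The expected move is a 1.1-fold lower number from compound 2 to compound 3 (0.04 log units; within the scatter) and so stays within that scatter. The expectation is anchored on compound 2 at 10500 nM as the closest measured structure. For compound 3 the estimate is 9500 nM with an expected range from 4000 nM to 22000 nM as its limits.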

Compound 3, half-maximal inhibitory concentration: 8710 nM
Estimate against measurement, compound 3: 1.1-fold (0.04 log units) above; the measured number falls inside the stated range.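

In this assay, methyl in place of hydrogen on a saturated chain carbon bound to an oxygen on a saturated carbon gives a 1.2-fold lower number from compound 2 to compound 3 (0.08 log units; within the scatter). Within the data shown here, this is the first pair that differs in one place only, so methoxymethyl to ethoxymethyl is the one change with a direct reading, and on this reading compound 2 and compound 3 cannot be told apart in this test. The single step therefore shows that this position tolerates the added methyl without a shift beyond the scatter, and the repeat entries available in the series give a sense of how closely this test can agree with itself: the several entries of compound 1 in this assay, 4340 nM; 4270 nM (2 entries)

A single small step at this position does not show how far the chain can be extended, so a longer chain such as butoxymethyl remains an open question there. The compounds shown also leave open how a group of a different kind at the same place, such as an amine or a carboxylic acid, would read in this assay.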